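Lengthening the chain once more: compound 4

The source may report more compounds than this note shows. Statements on the series, on what has been measured and on what is new or still open speak of the compounds shown alone.

compound 1 `CC(C)[S+]([O-])CCCCN=C=S`: 10400 nM
compound 2 `[O-][S+](CCCCN=C=S)c1ccccc1`: 4330 nM
compound 3 `CC(C)[S+]([O-])CCCCCN=C=S`: 10300 nM

In an ADME assay on Vero cells (Chlorocebus sabaeus) for cytotoxicity, read by MTT assay, with a stated time of 72 h (on this read-out higher numbers stand for weaker inhibition and lower numbers for stronger inhibition), compound 3 gives 10300 nM. That is level with compound 1 within the scatter, and clearly higher than compound 2. Compound 4 `CC(C)[S+]([O-])CCCCCCN=C=S` differs from compound 3 by a group of 4 heavy atoms (2 carbon, 1 nitrogen, 1 sulfur; no ring) in place of a group of 3 heavy atoms (1 carbon, 1 nitrogen, 1 sulfur; no ring), on a saturated chain carbon, five bonds along the chain from a sulfur. Within the data shown here, one measured step bears on this, the same kind of replacement four bonds along the chain from a sulfur: a 1.0-fold lower number from compound 1 to compound 3 (0.00 log units; within the scatter). Among the measured compounds shown here, that step lies within the scatter, but it is only a single example. No step beyond the scatter is therefore expected in this assay. The expected step is a 1.1-fold lower number from compound 3 to compound 4 (0.04 log units; within the scatter). Compound 4 is estimated at 9500 nM, with an expected range of 5000 nM to 17000 nM.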

Compound 4, half-maximal inhibitory concentration: 7310 nM
Estimate against measurement, compound 4: 1.3-fold (0.11 log units) above, within the range that was stated.
By their numbers in this assay, from the lowest: compounds 2, 4, 3 and 1 (each within the scatter of the next, the first and the last beyond it).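

The same replacement, now five bonds along the chain from a sulfur, gives a 1.4-fold lower number from compound 3 to compound 4 (0.15 log units; within the scatter) in this assay. Together with a 1.0-fold lower number from compound 1 to compound 3 (0.00 log units; within the scatter), this makes a second example, so the replacement has produced no step beyond the scatter at either place. Still open, as far as these compounds go, is how a longer chain, or an amine at the end of the chain, would read in this assay, and no measurement at hand offers an explanation for the numbers seen at this position.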